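A Chloro for an Isopropyl on a Weak Anilide

This account rests on a few compounds, and the source may have more. Where it says the series, first, only, none or still open, it means among the compounds named here.

Compound 2 `CC(C)c1ccc(NCC(=O)N[C@H]2CCOC2=O)cc1` is tested in a functional assay on MGC-803 cells (Homo sapiens) for antiproliferative activity, read by MTT assay, with a stated time of 72 h; a higher number here means a weaker inhibitor, a lower number a stronger inhibitor. Compound 2 gives > 64000 nM, which is a limit of the assay rather than a number. On the numbers shown compound 2 therefore stands at the edge of what the assay can report, because of the limit of > 64000 nM in this assay, at which 1 of the 3 values shown sits. Two further compounds share part of their structure with compound 2 but carry a different core: compound 1 `COc1ccccc1/C=C/C(=O)c1ccc(OCC(=O)N[C@H]2CCOC2=O)cc1` gives 39400 nM in this assay, and compound 3 `O=C(COc1ccc(C(=O)/C=C/c2ccc(Br)cc2)cc1)N[C@H]1CCOC1=O` gives 51000 nM. For the measured compounds named here, the only measured step, a 1.3-fold higher number from compound 1 to compound 3 (0.11 log units; within the scatter), exchanges one aryl group for another on that other core and stays within the scatter.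

Compound 4 `O=C(CNc1ccc(Cl)cc1)N[C@H]1CCOC1=O` differs from compound 2 by chloro in place of isopropyl on an aromatic carbon. Going by the values given here, no measured step changes this position on this core, and the one known step, on another core and within the scatter, gives little guidance. The expected step in this assay is then a number no higher from compound 2 to compound 4 (the limit leaves the size open), meaning no change beyond the scatter. Compound 4 is estimated at 64000 nM, in a range from 30000 nM to 150000 nM.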

Compound 4, half-maximal inhibitory concentration: > 64000 nM
Compound 4: no number, only a limit; the forecaster's own chance of this, stated with the estimate: 60%; the middle value sits exactly at the limit.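

Compound 2 and compound 4 both give a limit of this assay rather than a number, so no step can be read between them: the limit of > 64000 nM in this assay, at which 2 of the 4 values shown sit. The compounds shown leave open whether chloro in place of isopropyl changes antiproliferative activity at all on this core.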